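Chain homologation in an aminothiazole guanidine series

A few compounds are considered here, and "the series" means these few. Any claim that something is new, unique, unknown or untested is made for them only; others in the source may bear on it.

Measured so far, in an assay on membranes from Sf9 cells for displacement of a labelled ligand from histamine H2 receptor (Homo sapiens), read by scintillation counting, with a stated time of 60 min; a higher number here means a weaker inhibitor, a lower number a stronger inhibitor:
compound 1, `Cc1nc(N)sc1CCCN/C(N)=N/C(=O)NCC(C)CCc1ccccc1`, gives 63.1 nM
compound 2, `N/C(=N\C(=O)NCc1ccccc1)NC1CCc2nc(N)sc2C1`, gives 513 nM
compound 3, `Cc1nc(N)sc1CCCN/C(N)=N/C(=O)Nc1ccccc1`, gives 3160 nM

Compound 1 holds the lowest number of the three, and its gaps to compound 2 and to compound 3 both lie beyond the usual scatter, so it is the strongest inhibitor of this set.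

Compound 4, `Cc1nc(N)sc1CCCN/C(N)=N/C(=O)NCC(C)CCCc1ccccc1`, is not yet measured. It differs from compound 1 only by benzyl in place of phenyl on a saturated chain carbon, four bonds along the chain from an amide-type nitrogen. Among the compounds with values here, no measured pair shows this kind of change, so the expected step in this assay is small, in either direction, and likely within the scatter. Compound 4 is expected to give 80 nM, between 25 nM and 250 nM. The expected step of a 1.3-fold higher number from compound 1 to compound 4 (0.10 log units; within the scatter) reflects that uncertainty.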

Compound 4, inhibition constant: 60.3 nM
The estimate for compound 4 lay 1.3-fold (0.12 log units) above the measured number; the measured number falls inside the stated range.
By their numbers in this assay, from the lowest: compounds 4 and 1 (each within the scatter of the next); then compound 2; then compound 3.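

Benzyl in place of phenyl on a saturated chain carbon, four bonds along the chain from an amide-type nitrogen, gives a 1.0-fold lower number from compound 1 to compound 4 (0.02 log units; within the scatter), so compound 1 and compound 4 stand level. Within the data shown here, this is the first step read at a single place, and it shows that the number at this position holds across this one-carbon difference. Nothing available bears on why the two stand level.

As far as these compounds go, whether phenethyl or 3-phenylpropyl at this place would keep the number level remains open. So does the outcome of putting an amine or a carboxylic acid there in place of the aromatic ring.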